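The compounds below may be only part of what the source reports. "The series", "measured", "known", "first", "only" and "open" are said of these compounds alone.

In an in vitro ADME assay on microsomes (Rattus norvegicus) for metabolic stability (on this read-out higher numbers stand for a longer-lived compound and lower numbers for a shorter-lived compound), compound 2 `CCc1nc(-c2ccc(Cl)cc2Cl)c(CC)nc1SC(C)CC` gives 0.0683 h, the higher of two numbers but within the scatter of compound 1 `CCc1nc(-c2ccc(Cl)cc2Cl)c(CC)nc1NC(COC)COC` at 0.0417 h. Compound 3 `CCCN(CC1CC1)c1nc(CC)c(-c2ccc(Cl)cc2Cl)nc1CC` carries (cyclopropylmethyl)(propyl)amino in place of (sec-butyl)sulfanyl on an aromatic carbon. Within the data shown here, the only measured step at this place is a 1.6-fold higher number from compound 1 to compound 2 (0.21 log units; within the scatter), an exchange between an amino group and the same sulfanyl group. No step beyond the scatter is therefore expected in this assay, and the expected step is a 1.4-fold lower number from compound 2 to compound 3 (0.14 log units; within the scatter). The estimate for compound 3 is 0.05 h, with an expected range from 0.02 h to 0.12 h.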

Compound 3, half-life: 0.07 h
For compound 3 the middle estimate is 1.4-fold (0.15 log units) below the measured one, within the range that was stated.
By their numbers in this assay, from the lowest: compounds 1, 2 and 3 (each within the scatter of the next).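

In this assay, replacing (sec-butyl)sulfanyl with (cyclopropylmethyl)(propyl)amino, which brings a three-membered ring of carbon only, gives a 1.0-fold higher number from compound 2 to compound 3 (0.01 log units; within the scatter), while exchanging the two amino groups gives a 1.7-fold higher number from compound 1 to compound 3 (0.22 log units; within the scatter). All three groups on this aromatic carbon, joined through sulfur or nitrogen and with or without a ring, therefore lie within the scatter of one another. No evidence is available that bears on this result. From the compounds shown here alone, it remains open whether a carboxylic acid or a primary amine at this place would give a step beyond the scatter. Going by these compounds, the effect of changing the ethyl groups on the shared core also remains open.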